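The source may report more compounds than this note shows. Statements on the series, on what has been measured and on what is new or still open speak of the compounds shown alone.

Among the compounds with values here, in a functional assay on A2780 cells (Homo sapiens) for inhibition, read by sulforhodamine B assay (a lower number here means a stronger inhibitor of growth, a higher number a weaker inhibitor of growth), compound 2 (`Oc1cccc2[nH]c(-c3ccc(-c4ccc(-c5ccc(F)cc5)cc4)cc3)nc12`) gives 41200 nM and stands within the scatter of compound 1 (`Oc1cccc2[nH]c(-c3ccc(-c4ccc(-c5ccccc5)cc4)cc3)nc12`) with 41000 nM as the only other number so far. Compound 3 (`Oc1cccc2[nH]c(-c3ccc(-c4ccc(-c5ccc(C(F)(F)F)cc5)cc4)cc3)nc12`) has trifluoromethyl in place of fluoro on an aromatic carbon, para to a large group (trifluoromethyl in place of fluoro on an aromatic carbon). Within the data shown here, the one measured step at this place is a 1.0-fold higher number from compound 1 to compound 2 (0.00 log units; within the scatter) for fluoro in place of hydrogen, and trifluoromethyl itself is untested. An expected 1.0-fold lower number from compound 2 to compound 3 (0.01 log units; within the scatter) therefore means no shift beyond the scatter in either direction. Compound 3 is estimated at 40000 nM (expected range 20000 nM to 80000 nM).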

Compound 3, concentration for 50% growth inhibition: 6100 nM
For compound 3 the middle estimate is 6.6-fold (0.82 log units) above the measured one; measured number outside the range, below it.
By their numbers in this assay, from the lowest: compound 3; then compounds 1 and 2 (each within the scatter of the next).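

At this position, this assay responds to the substituent after all: trifluoromethyl gives a 6.8-fold lower number from compound 2 to compound 3 (0.83 log units; beyond the scatter) and a 6.7-fold lower number from compound 1 to compound 3 (0.83 log units; beyond the scatter), whereas hydrogen and fluoro showed only a 1.0-fold higher number from compound 1 to compound 2 (0.00 log units; within the scatter). The flat step from hydrogen to fluoro therefore did not mean that this position was insensitive to change. Nothing available explains why trifluoromethyl differs from fluoro here.

Going by these compounds, whether the shift is particular to trifluoromethyl remains open, as a methoxy group, an amine, a carboxylic acid or a longer alkyl chain at this position could separate the possibilities. On these data alone, whether the same change acts alike on other substituted cores also remains open.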